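A few compounds are considered here, and "the series" means these few. Any claim that something is new, unique, unknown or untested is made for them only; others in the source may bear on it.

Of the compounds shown here, three have so far been measured in a physicochemical assay for acid dissociation. Compound 1 `Cc1nc2c(OCc3ccccc3)cccn2c1CO` gives 6.1. Compound 2 `Cc1nc2c(CCc3ccccc3)nccn2c1N` gives 5.1 in this assay. Compound 3 `Cc1nc2c(OCc3ccccc3)nccn2c1N` gives 4.6 in this assay, and that is the lowest of the three numbers: the nearest to it is compound 2, which lies higher by a margin beyond the scatter, and the furthest is compound 1, which lies higher still, again beyond the scatter. Compound 1 and compound 2 each differ from compound 3 in more than one place, so neither pair isolates a single change.

The next compound, compound 4 `Cc1nc2c(OCc3ccccc3)nccn2c1C`, is built from compound 3 by one change: methyl in place of amino on an aromatic carbon. Among the compounds with values here, no measured pair shows this exchange on its own, so its size in this assay is not known from the data. Within the data shown here, the only guide is that compound 1, which carries neither amino nor methyl at that carbon, sits higher than compound 3 while also differing in its core, which does not settle the matter. The step from compound 3 to compound 4 is therefore expected to be small, a number 0.10 log units higher from compound 3 to compound 4 (within the scatter), and not clearly beyond the scatter. Compound 4 is expected to give 4.7 in this assay, within a range from 4.1 to 5.3.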

Compound 4, acid dissociation constant: 4.8
For compound 4 the middle estimate is 0.10 log units below the measured one; low and high end bracket the measured number.
By their numbers in this assay, from the lowest: compounds 3, 4 and 2 (each within the scatter of the next, the first and the last beyond it); then compound 1.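

In this assay, within the data shown here, the exchange of amino for methyl now has a size of its own, since a number 0.20 log units higher from compound 3 to compound 4 (within the scatter) is the first step in the set that isolates a single change. It places the exchange on an aromatic carbon of a five-membered aromatic ring with 2 nitrogen, part of a fused or bridged system of two rings, where a group counted with 1 hydrogen-bond donor and 1 hydrogen-bond acceptor gives way to one counted with neither, and for this pair that swap does not move the read-out beyond the scatter. No independent measurement accompanies this result that would account for it.

As far as these compounds go, the pair speaks for one core only, so it remains open whether the same exchange would stay within the scatter on the core of compound 1 or on compound 2, which carries a two-carbon chain in place of the oxygen-linked group of compound 3. From the compounds shown here alone, it also remains open what a larger or differently built group on this same aromatic carbon, such as a dimethylamino group, a carboxylic acid or a longer alkyl chain, would do in this assay on the shared core.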